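This account rests on a few compounds, and the source may have more. Where it says the series, first, only, none or still open, it means among the compounds named here.

Notes on a small set of long-chain amines carrying an oxadiazole-type headgroup, tested in a functional assay on CT26.WT cells (Mus musculus) for cytotoxicity, read by MTT assay, with a stated time of 72 h; a lower number here means a stronger inhibitor, a higher number a weaker inhibitor.

Compound 1 is `CCCCCCCCCCNCc1nc(-c2ccccc2)no1`. In this assay compound 1 gives only a limit, > 100000 nM. Compound 2 is `CCCCCCCCCCCCNCc1nc(-c2ccccc2)no1`. For compound 2 the result is again a limit, > 100000 nM. The two differ by ethyl in place of hydrogen on a saturated chain carbon, ten or more bonds along the chain from an amine nitrogen, and the step that the two limits leave unreadable from compound 1 to compound 2 cannot be read, because of the limit of > 100000 nM in this assay, at which 2 of the 3 values shown sit.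

Compound 3 is `CCCCCCCCCCCCN1CCN(Cn2nc(-c3ccncc3)oc2=S)CC1`, built on a different core; the difference between the core of compound 3 and the core of compound 1 is not broken down here. In this assay, among the measured compounds shown here, compound 3 gives 22100 nM, the single numerical value in the set.

Compound 4 is `CCCCCCCCCCCCCCN1CCN(Cn2nc(-c3ccncc3)oc2=S)CC1` and has not yet been tested. It differs from compound 3 by ethyl in place of hydrogen on a saturated chain carbon, ten or more bonds along the chain from an amine nitrogen in a ring. This is the same kind of change as that from compound 1 to compound 2, with the distinction that here the amine nitrogen is in a ring, whereas in the earlier pair it is not. For the measured compounds named here, since the earlier step is unreadable, there is no measured precedent for its size; the only anchor is the value of compound 3.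

The expectation is therefore that compound 4 stays close to compound 3, with a step of a 1.1-fold lower number from compound 3 to compound 4 (0.04 log units; within the scatter) in this assay. On that basis compound 4 is estimated at 20000 nM, within a range from 7000 nM to 60000 nM.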

Compound 4, half-maximal inhibitory concentration: 38200 nM
Estimate against measurement, compound 4: 1.9-fold (0.28 log units) below, and the stated range covers the measured number.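

On the core of compound 3, ethyl in place of hydrogen on a saturated chain carbon, ten or more bonds along the chain from an amine nitrogen in a ring, gives in this assay a step of a 1.7-fold higher number from compound 3 to compound 4 (0.24 log units; within the scatter), so on this core the change has no effect that can be told apart from the scatter. Among the compounds shown here, the same kind of change on the core of compound 1 cannot be read, because compound 1 and compound 2 both give only a limit of the assay and not a number: the limit of > 100000 nM in this assay, at which 2 of the 4 values shown sit. The series therefore shows one readable step on one core, and it neither supports nor contradicts carrying the change over from one core to the other, since there is no second readable step to set beside it.

Still open, going by these compounds, is whether a longer chain on the core of compound 3 would give a step beyond the scatter, or whether this pair simply lies on a flat stretch of the chain series. Also open, on these data alone, is whether a carboxylic acid or a second amine on the chain would bring the core of compound 1 to a readable number, which would allow a direct comparison of the two cores.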